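Opening a five-membered acetal: from aminomethyl to a longer amine

The compounds below may be only part of what the source reports. "The series", "measured", "known", "first", "only" and "open" are said of these compounds alone.

Measured so far:
compound 1, `CCC[C@]1(c2ccccc2)OC[C@H]([C@@H]2CCCCN2)O1`, 69 nM
compound 2, `CC[C@]1(c2cccc(N)c2)OC[C@H]([C@@H]2CCCCN2)O1`, 1230 nM
compound 3, `NC[C@H]1COC(c2ccccc2)(c2ccccc2)O1`, 1400 nM

In a functional assay (brain) for displacement of a labelled ligand, with Rattus norvegicus as the target (on this read-out higher numbers stand for weaker inhibition and lower numbers for stronger inhibition), compound 3 gives 1400 nM, the highest number of the three. Compound 2, with 1230 nM, lies within the usual scatter of it, so the two cannot be told apart. Compound 1, at 69 nM, sits well beyond the scatter and marks clearly stronger inhibition than compound 3.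

Compound 4, `CCC[C@H](NC)[C@H]1COC(c2ccccc2)(c2ccccc2)O1`, has not yet been measured. It differs from compound 3 in one place: 1-(methylamino)butyl in place of aminomethyl on a saturated ring carbon. The aminomethyl group on the saturated ring carbon of the shared core is exchanged for a larger group that keeps one hydrogen-bond donor and one hydrogen-bond acceptor but brings a defined stereocentre.

Among the measured compounds shown here, no measured pair shows this exact change, so the expectation rests on the three values alone. A modest step toward stronger inhibition is expected, a 3.5-fold lower number from compound 3 to compound 4 (0.54 log units; beyond the scatter), since the more elaborate amines of compound 1 and compound 2 accompany the lower numbers. Compound 4 is therefore estimated at 400 nM in this assay, with a plausible range from 100 nM to 2000 nM.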

Compound 4, inhibition constant: 7000 nM
The estimate for compound 4 lay 18-fold (1.24 log units) below the measured number; measured number outside the range, above it.
By their numbers in this assay, from the lowest: compound 1; then compounds 2 and 3 (each within the scatter of the next); then compound 4.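

In this assay, putting 1-(methylamino)butyl in place of aminomethyl on this saturated ring carbon gives a 5.0-fold higher number from compound 3 to compound 4 (0.70 log units; beyond the scatter), so on this core with its two phenyl groups the longer amine side chain goes with weaker inhibition, not stronger. The two groups have the same hydrogen-bond donor and acceptor counts, but the extra carbons, the methyl on the nitrogen and the new defined stereocentre all arrive in this one step, and the pair cannot separate them. Nothing measured here explains the rise in the number.

Still open, as far as these compounds go, is whether 1-aminobutyl, which has the same chain without the methyl on the nitrogen, or the shorter 1-(methylamino)ethyl would lie closer to compound 3 or to compound 4. The opposite arrangement at the new stereocentre also remains to be compared with compound 4.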